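Replacing 2,6-Dibromophenyl with 2,6-Difluorophenyl on a Shared Core

This account rests on a few compounds, and the source may have more. Where it says the series, first, only, none or still open, it means among the compounds named here.

In an ADME assay on Huh-7 cells (Homo sapiens) for cytotoxicity, read by MTT assay, with a stated time of 4 h, at 37 degrees C (a higher number here means that more compound is tolerated, a lower number that less compound is tolerated), compound 1 `Cn1c(=O)c(-c2c(Br)cccc2Br)cc2c(N)nc(Nc3ccccc3)nc21` gives 800 nM and so holds the lower of the two numbers available. Compound 2 `O=C1Nc2nc(Nc3ccccc3)[nH]c(=O)c2CC1c1c(F)cccc1F` gives 5300 nM and lies higher by more than the usual scatter. Compound 3 `Cn1c(=O)c(-c2c(F)cccc2F)cc2c(N)nc(Nc3ccccc3)nc21` keeps the core of compound 1 but carries 2,6-difluorophenyl in place of 2,6-dibromophenyl on an aromatic carbon. Among the measured compounds shown here, no measured pair isolates this change. For the measured compounds named here, the only guide is compound 2 at 5300 nM which bears 2,6-difluorophenyl on another core, so a rise in this assay is expected for compound 3, though one that stops short of that number. The expected step is a 2.5-fold higher number from compound 1 to compound 3 (0.40 log units; beyond the scatter) and would lie modestly beyond the scatter. Compound 3 is estimated at 2000 nM with 700 nM to 6000 nM as the expected range.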

Compound 3, half-maximal cytotoxic concentration: 10400 nM
Beside the measured number, compound 3's estimate is 5.2-fold (0.72 log units) below it; the whole stated range lies below it.
By their numbers in this assay, from the lowest: compound 1; then compounds 2 and 3 (each within the scatter of the next).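

On the core of compound 1, this assay now gives a direct reading of this exchange: 2,6-difluorophenyl in place of 2,6-dibromophenyl on an aromatic carbon brings a 13-fold higher number from compound 1 to compound 3 (1.11 log units; beyond the scatter) and so marks a large step at this position. The two groups have the same computed count of heavy atoms, the same carbon-only aromatic ring, and no net charge, so this position is sensitive to a change of halogen even where those counts stay equal. Nothing shown gives a reason for the size of the step.

The compounds shown leave open where 2,6-dichlorophenyl or an unsubstituted phenyl would fall on the same core, and so whether the number follows the halogen in any regular way. They also leave open whether the same exchange would bring a similar step on a different core.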